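Nitro in place of hydrogen on a shared core

The source may hold more compounds than are shown below. What is called first, only, known or untested is meant among the compounds shown, and "the series" means these compounds.

Measured compounds:
compound 1, `Cc1ccc(Nc2nn(-c3ccc([N+](=O)[O-])cc3)c3nc(Nc4ccccc4)n(-c4ccccc4)c(=O)c23)cc1`: 39.8%
compound 2, `O=c1c2c(Nc3ccc(Cl)cc3)nn(-c3ccccc3)c2nc(Nc2ccccc2)n1-c1ccccc1`: 44%

In a functional assay on the whole organism (strain Wistar albino) for inhibition, with Rattus norvegicus as the target, read by paw edema, with a stated time of 2 h, at a dose of 25 mg/kg by the oral route (on this read-out lower numbers stand for less inhibition and higher numbers for more inhibition at the one dose given (going by the name of the read-out)), compound 2 gives 44%, the higher of the two numbers recorded, with compound 1 the nearest at 39.8%, a gap that lies within the scatter, so the two cannot be set in any order. Compound 3, `O=c1c2c(Nc3ccc(Cl)cc3)nn(-c3ccc([N+](=O)[O-])cc3)c2nc(Nc2ccccc2)n1-c1ccccc1`, has not yet been measured. It differs from compound 2 by nitro in place of hydrogen on an aromatic carbon, on an aromatic carbon of a six-membered aromatic ring of carbon only, para to a large group. Among the compounds with values here, no step between measured compounds shows what this change alone does here. Compound 1 also carries a nitro group and gives 39.8%, a number within the scatter of compound 2, so a step of no size beyond the scatter is expected. Compound 3 is therefore estimated at 42% in this assay, with a range from 30% to 54%, which means an expected step of a number 2 percentage points lower from compound 2 to compound 3 (within the scatter).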

Compound 3, a percentage reported as inhibition, in the whole organism at one dose (the size of the read-out at that dose, not a potency): 39%
Estimate against measurement, compound 3: 3 percentage points above; low and high end bracket the measured number.
By their numbers in this assay, from the lowest: compounds 3, 1 and 2 (each within the scatter of the next).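

In this assay the change from phenyl to 4-nitrophenyl now has a step of its own (a number 5 percentage points lower from compound 2 to compound 3 (within the scatter)), so on an aromatic carbon para to a large group, nitro in place of hydrogen cannot be told apart from the unchanged compound on this read-out. With the nitro group present in both compounds, chloro in place of methyl on an aromatic carbon likewise stays inside the scatter (a number 0.8 percentage points lower from compound 1 to compound 3 (within the scatter)). Nothing at hand explains either step.

From the compounds shown here alone, whether another group at this place, such as an amine or a carboxylic acid, would give a step beyond the scatter remains open. Going by these compounds, it is also open whether the nitro step would look the same at another dose or at another time after dosing.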